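Sulfonyl group swap on the top compound of the series

The source may hold more compounds than are shown below. What is called first, only, known or untested is meant among the compounds shown, and "the series" means these compounds.

Measured in a functional assay on HL-60 cells (Homo sapiens) for inhibition, read by CCK-8 assay, with a stated time of 48 h, tested at 20 uM; a higher number here means more inhibition of growth at the concentration tested, a lower number less inhibition of growth:
compound 1 `COc1ccc(S(=O)(=O)Oc2ccccc2/C=C(\C#N)C(=O)Nc2nnc(-c3cccs3)s2)cc1`: 67%
compound 2 `COc1ccc(S(=O)(=O)Nc2cccc(/C=C(\C#N)C(=O)Nc3nnc(-c4cccs4)s3)c2)cc1`: 77%
compound 3 `COc1ccc(Cc2nnc(NC(=O)/C(C#N)=C/c3ccccc3OS(=O)(=O)c3ccc(OC)cc3)s2)cc1`: 100%

Compound 3 stands highest of the three at 100%, clear of compound 2 at 77% and of compound 1 at 67%. The next compound, compound 4 `COc1ccc(Cc2nnc(NC(=O)/C(C#N)=C/c3ccccc3OS(=O)(=O)c3ccccc3[N+](=O)[O-])s2)cc1`, differs from compound 3 only in the group on the sulfonyl sulfur: 2-nitrophenyl in place of 4-methoxyphenyl on a sulfonyl sulfur. In words, this is 2-nitrophenyl in place of 4-methoxyphenyl.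

Among the compounds with values here, the one measured single-change step, a number 33 percentage points higher from compound 1 to compound 3 (beyond the scatter), comes from 4-methoxybenzyl in place of thiophen-2-yl on an aromatic carbon. It is large, but it concerns a different change. All three measured compounds carry 4-methoxyphenyl on the sulfonyl sulfur, so the data give no direct measure for this swap. Within the data shown here, that step shows only that one change can move this assay substantially.

With compound 3 already at 100%, there is little room for a rise, so any step beyond the scatter is more likely to be downward. The expected step is moderate: a number 15 percentage points lower from compound 3 to compound 4 (beyond the scatter). Compound 4 is estimated at 85%, with an expected range of 60% to 100%.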

Compound 4, percent growth inhibition at one concentration: 25%
Compound 4: the middle estimate sits 60 percentage points above what was measured; the measured number lies below the stated range.
By their numbers in this assay, from the lowest: compound 4; then compounds 1 and 2 (each within the scatter of the next); then compound 3.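

In this assay, within the data shown here, the group on the sulfonyl sulfur turns out to matter strongly, a point the earlier compounds could not address since all of them carry 4-methoxyphenyl there: with 2-nitrophenyl in place of 4-methoxyphenyl and the rest of the structure unchanged, the result is a number 75 percentage points lower from compound 3 to compound 4 (beyond the scatter). The earlier step, a number 33 percentage points higher from compound 1 to compound 3 (beyond the scatter), had pointed to 4-methoxybenzyl as favourable, but the new step shows that this group does not secure high growth inhibition whatever sits on the sulfonyl sulfur. No measurement at hand accounts for the drop.

This swap changes both the substituent and its place on the ring, so the compounds shown cannot separate the nitro group from its 2-position, a question that 4-nitrophenyl and 2-methoxyphenyl on the sulfonyl sulfur would bear on directly, with unsubstituted phenyl or 4-aminophenyl as further points of comparison. Also open, going by these compounds, is whether 2-nitrophenyl would have a similar effect with thiophen-2-yl in place of 4-methoxybenzyl, as in compound 1.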